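Replacing 4-methoxyphenyl with 2-fluorophenyl in compound 1

This account rests on a few compounds, and the source may have more. Where it says the series, first, only, none or still open, it means among the compounds named here.

- compound 1 `COc1ccc(/C=C/C(=O)c2ccc(Nc3cc(C)nc4nc(SCc5nc6ccccc6[nH]5)nn34)cc2)cc1` measured at 170 nM
- compound 2 `Cc1cc(Nc2ccc(C(=O)/C=C/c3ccc4ccccc4c3)cc2)n2nc(SC(=O)c3csc4ccc(Cl)cc34)nc2n1` measured at 35 nM
- compound 3 `Cc1cc(Nc2ccc(C(=O)/C=C/c3ccc4ccccc4c3)cc2)n2nc(SCc3nc4ccccc4[nH]3)nc2n1` measured at 5 nM
- compound 4 `Cc1cc(Nc2ccc(C(=O)/C=C/c3ccccc3F)cc2)n2nc(SCc3nc4ccccc4[nH]3)nc2n1` not yet measured

In a functional assay on SW-620 cells (Homo sapiens) for cytotoxicity, read by MTT assay, with stated times of 4 h and 72 h, tested at 2 uM (a higher number here means a weaker inhibitor, a lower number a stronger inhibitor), compound 1 has the highest number of the three (170 nM) and is therefore the weakest inhibitor among them.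

Compound 4 differs from compound 1 in one place, on a double-bonded chain carbon bound to a double-bonded chain carbon: 2-fluorophenyl in place of 4-methoxyphenyl on a double-bonded chain carbon bound to a double-bonded chain carbon and the rest of the structure stays the same.

The most relevant evidence is the change at this same place, a 34-fold lower number from compound 1 to compound 3 (1.53 log units; beyond the scatter) and this large drop came with naphthalen-2-yl as the new group. The other measured change, a 7.0-fold lower number from compound 2 to compound 3 (0.85 log units; beyond the scatter) and it lies on a sulfur, so it says little about this swap. Only one replacement at this place has been measured, and 2-fluorophenyl, like 4-methoxyphenyl, has one six-membered aromatic ring, so a full repeat of the drop to compound 3 seems unlikely.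

In this assay a moderate drop is therefore expected, estimated as a 3.4-fold lower number from compound 1 to compound 4 (0.53 log units; beyond the scatter) and smaller than the drop seen with naphthalen-2-yl. The estimated value for compound 4 is 50 nM (expected range 8 nM to 250 nM).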

Compound 4, half-maximal inhibitory concentration: 250 nM
Compound 4: the middle estimate sits 5.0-fold (0.70 log units) below what was measured; measured number inside the range.
By their numbers in this assay, from the lowest: compound 3; then compound 2; then compounds 1 and 4 (each within the scatter of the next).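

In this assay, replacing 4-methoxyphenyl with 2-fluorophenyl gives a 1.5-fold higher number from compound 1 to compound 4 (0.17 log units; within the scatter), so this assay does not separate these two single-ring groups, although one brings an oxygen and the other a fluorine. At the same place, replacing naphthalen-2-yl with 2-fluorophenyl gives a 50-fold higher number from compound 3 to compound 4 (1.70 log units; beyond the scatter), which shows that the large difference seen earlier is not tied to 4-methoxyphenyl alone: among the three groups compared here, naphthalen-2-yl stands apart from both groups built on one six-membered aromatic ring. Nothing available explains why these groups give these numbers.

From the compounds shown here alone, whether a naphthalen-1-yl group, or a phenyl ring carrying an amine or a carboxylic acid, would come close to compound 3 remains open. Going by these compounds, it is also open whether 2-fluorophenyl and 4-methoxyphenyl would still give close numbers with (5-chloro-1-benzothiophen-3-yl)carbonyl on the sulfur in place of (1H-benzimidazol-2-yl)methyl.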